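Bromomethyl in place of the dienyl chain on compound 2

A few compounds are considered here, and "the series" means these few. Any claim that something is new, unique, unknown or untested is made for them only; others in the source may bear on it.

Measured so far:
compound 1 `COc1ccc(CNc2cc(OC)c(OC)c(OC)c2)cc1C`: 60900 nM
compound 2 `C/C=C/C=C/C(=O)N(Cc1ccc(OC)c(O)c1)c1cc(OC)c(OC)c(OC)c1`: 180 nM
compound 3 `COc1cc(NCc2cccc(O)c2)cc(OC)c1OC`: 67700 nM

In a functional assay on HCT-116 cells (Homo sapiens) for inhibition, read by MTT assay, with a stated time of 48 h (on this read-out higher numbers stand for weaker inhibition and lower numbers for stronger inhibition), compound 2 gives 180 nM, the lowest number of the three; compound 1 and compound 3 both sit far higher, beyond the scatter. Compound 4 `COc1ccc(CN(C(=O)CBr)c2cc(OC)c(OC)c(OC)c2)cc1O` keeps the amide of compound 2 but differs in one place: bromomethyl in place of penta-1,3-dien-1-yl on a carbonyl carbon. Among the compounds with values here, no step between measured compounds covers this change, so the expectation rests on compound 2 alone. The estimate for compound 4 is a moderately higher number than compound 2, a step of a 2.8-fold higher number from compound 2 to compound 4 (0.44 log units; beyond the scatter) that is expected to lie beyond the scatter, though its size is uncertain. The value expected for compound 4 is 500 nM, within a range from 80 nM to 4000 nM.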

Compound 4, half-maximal inhibitory concentration: 68 nM
The estimate for compound 4 lay 7.4-fold (0.87 log units) above the measured number, and the stated range ends above it.
By their numbers in this assay, from the lowest: compound 4; then compound 2; then compounds 1 and 3 (each within the scatter of the next).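

In this assay, putting bromomethyl in place of penta-1,3-dien-1-yl on a carbonyl carbon gives a 2.6-fold lower number from compound 2 to compound 4 (0.42 log units; beyond the scatter), a modest step. At this position, then, neither the dienyl chain nor its two double bonds are needed for a low number, and a group of only two heavy atoms does at least as well. Nothing measured here accounts for this step. Going by these compounds, it remains open whether the bromine itself matters, since methyl or chloromethyl on the same carbonyl carbon would test this. On these data alone, how a longer chain carrying bromine would compare also remains open.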